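The source may report more compounds than this note shows. Statements on the series, on what has been measured and on what is new or still open speak of the compounds shown alone.

Working notes on the series. Two members of the series have a number in an ADME assay on microsomes from liver (Homo sapiens) for metabolic stability; a higher number here means faster removal of the compound, a lower number slower removal. Compound 1 `CC(C)n1nc(-c2ccnc3[nH]c(C4CCN(CC(=O)N(C)C)CC4)cc23)ccc1=O` gives 13 uL/min in this assay. Compound 2 `CC(C)Cn1cc(-c2ccnc3[nH]c(C4CCN(CC(=O)N(C)C)CC4)cc23)ccc1=O` gives 21 uL/min in this assay; its number sits within the scatter of the number of compound 1, so the two cannot be told apart on the data so far. Compound 3 `CC(C)n1cc(-c2ccnc3[nH]c(C4CCN(CC(=O)N(C)C)CC4)cc23)ccc1=O` is the next member to go into this assay. Its structural change from compound 2 is isopropyl in place of isobutyl on an aromatic nitrogen. Within the data shown here, no measured pair shows this change on its own, so the size of the step has to be judged without a direct precedent. The expectation is that the step from compound 2 to compound 3 in this assay stays within the scatter, a 1.3-fold lower number from compound 2 to compound 3 (0.12 log units; within the scatter), leaning if anything slightly downward. On that basis compound 3 is estimated at 16 uL/min in this assay, with a range from 9 uL/min to 28 uL/min.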

Compound 3, intrinsic clearance in a liver preparation (reported as CLH), per the amount of preparation that the assay uses: < 3 uL/min
Compound 3: no number, only a limit; the forecaster's own chance of this, stated with the estimate: 3%; middle value at least 5.3-fold (0.72 log units) away from the limit.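

In this assay compound 3 gives no number, only a limit of the assay: the limit of < 3 uL/min in this assay, at which 1 of the 3 values shown sits. The swap of isobutyl for isopropyl on the aromatic nitrogen gives an at least 7.0-fold lower number from compound 2 to compound 3 (0.84 log units; beyond the scatter), so this position responds to the change of alkyl group alone, beyond the scatter. Among these compounds, with isopropyl held constant, the six-membered aromatic ring with 1 hetero atom in place of the one with 2 hetero atoms gives an at least 4.3-fold lower number from compound 1 to compound 3 (0.63 log units; beyond the scatter), so the ring matters as well, which the earlier compounds could not show.

On these data alone, both steps are bounds, so their true sizes remain open. As far as these compounds go, whether the response on this nitrogen follows chain length or branching also remains open, and an ethyl, a cyclopropyl or a tert-butyl group there would bear on it.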